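The source may report more compounds than this note shows. Statements on the series, on what has been measured and on what is new or still open speak of the compounds shown alone.

Working notes on the series. Compound 1 `CC[C@H](NC(=O)c1c(CN2CCC(N3CCCCC3)CC2)c(-c2cccc(C(F)(F)F)c2)nc2ccccc12)c1ccccc1` gives 160 nM in an assay on HEK293 cells for antagonist activity at transient receptor potential cation channel subfamily V member 4 (Homo sapiens), read by FLIPR and calcium flux, with a stated time of 10 min; a higher number here means a weaker inhibitor, a lower number a stronger inhibitor. Among the compounds with values here, compound 3 `O=C(NC1(c2ccccc2)CC1)c1c(CN2CCC(N3CCCCC3)CC2)c(-c2cccc(C(F)(F)F)c2)nc2ccccc12` gives 50 nM in this assay, and the one single-point change measured so far is a 3.2-fold lower number from compound 1 to compound 3 (0.51 log units; beyond the scatter), on the amide nitrogen rather than the aryl group. Compound 2 `COc1ccc(-c2nc3ccccc3c(C(=O)N[C@@H](C)c3ccccc3)c2CN2CCC(N3CCCCC3)CC2)cc1` stands highest of the three numbers at 5010 nM, beyond the scatter from both of the others. Compound 4 `C[C@H](NC(=O)c1c(CN2CCC(N3CCCCC3)CC2)c(-c2ccc(Cl)cc2)nc2ccccc12)c1ccccc1` differs from compound 2 by chloro in place of methoxy on an aromatic carbon. Within the data shown here, no measured step touches this aryl position, so the size of the step has no direct precedent; the only measured step concerns the amide side and gives no guide here. Compound 4 is expected to give about 1500 nM, with a range of 400 nM to 6000 nM. That estimate means an expected step of a 3.3-fold lower number from compound 2 to compound 4 (0.52 log units; beyond the scatter).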

Compound 4, half-maximal inhibitory concentration: 320 nM
Beside the measured number, compound 4's estimate is 4.7-fold (0.67 log units) above it; measured number outside the range, below it.
By their numbers in this assay, from the lowest: compound 3; then compounds 1 and 4 (each within the scatter of the next); then compound 2.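

In this assay, within the data shown here, the 4-methoxyphenyl to 4-chlorophenyl change gives a 16-fold lower number from compound 2 to compound 4 (1.19 log units; beyond the scatter) and is the first measured step at this aryl position, showing that a single substituent here can strongly shift the number. The change swaps two heavy atoms for one and removes a hydrogen-bond acceptor, but no measured evidence links either difference to the step. This single pair leaves open whether the step carries over to compounds with the 1-phenylcyclopropyl amide. As far as these compounds go, how fluoro, nitrile or an amine would fare on this aromatic carbon also remains open.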